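A few compounds are considered here, and "the series" means these few. Any claim that something is new, unique, unknown or untested is made for them only; others in the source may bear on it.

Working notes on the series. Compound 1 `NCCCOc1ccc(CNc2nc3ccc(Oc4ccc(C(F)(F)F)cc4)cc3s2)cc1` and compound 2 `CN(Cc1ccc(OCCCN)cc1)c1nc2ccc(Oc3ccc(C(F)(F)F)cc3)cc2s1` share one core and differ only at a single nitrogen; compound 3 `CN(Cc1ccc(OCCCNC(=N)N)cc1)c1nc2ccc(Oc3ccc(F)cc3)cc2s1` carries another core, and the difference between the core of compound 3 and the core of compound 2 is not broken down here. In an assay on cells for inhibition of Voltage-dependent T-type calcium channel subunit alpha-1H (Homo sapiens), read by FLIPR and calcium flux, with stated times of 600 s and 300 s (a higher number here means a weaker inhibitor, a lower number a stronger inhibitor), compound 1 gives 112000 nM. In this assay compound 2 gives 248000 nM, and compound 3 gives 521000 nM, the highest number of the three. Among the measured compounds shown here, the one counted step inside the measured set is hydrogen in place of methyl on a nitrogen on an aromatic ring, and in this assay it gave a 2.2-fold lower number from compound 2 to compound 1 (0.35 log units; beyond the scatter).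

Compound 4 `N=C(N)NCCCOc1ccc(CNc2nc3ccc(Oc4ccc(F)cc4)cc3s2)cc1` is the not yet measured partner of compound 3. It differs from compound 3 by hydrogen in place of methyl on a nitrogen on an aromatic ring. The place of this change is the same word for word as in the pair of compound 2 and compound 1, so it is the same change, made twice among the compounds shown. For compound 4 in this assay a step of about the size of the earlier one is expected, namely a 2.1-fold lower number from compound 3 to compound 4 (0.32 log units; beyond the scatter). This rests on compound 2 and compound 1, where the same change gave a 2.2-fold lower number from compound 2 to compound 1 (0.35 log units; beyond the scatter), with the caution that a single pair carries it and that the cores are not the same. Compound 4 is accordingly estimated at 250000 nM in this assay, with a range from 120000 nM to 520000 nM expected.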

Compound 4, half-maximal inhibitory concentration: 288000 nM
For compound 4 the middle estimate is 1.2-fold (0.06 log units) below the measured one, within the range that was stated.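

The same change on the second core in this assay gives a 1.8-fold lower number from compound 3 to compound 4 (0.26 log units; within the scatter), a step that, taken alone, cannot be told apart from the scatter of repeated measurements. Set beside the earlier step, it shows that hydrogen in place of methyl on a nitrogen on an aromatic ring carried over from one core to the other with a size that cannot be told apart from the first: the same change on two cores in this assay, a 2.2-fold lower number (0.35 log units; beyond the scatter) from compound 2 to compound 1 and a 1.8-fold lower number (0.26 log units; within the scatter) from compound 3 to compound 4, 1.2-fold (0.09 log units) apart, within the scatter of two such steps

This does not show a firm preference for hydrogen on the second core, and two pairs, both with high numbers, say nothing about how the change behaves on other cores or in compounds with much lower numbers.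

The compounds shown carry only hydrogen or methyl on this nitrogen, so it remains open whether an ethyl, a cyclopropyl or an acetyl there would fit the same small step or break from it. Also open, on these data alone, is whether the step keeps its size when the chain bearing the terminal group is shorter or longer, or when that group is a carboxylic acid or an amide.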